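Swapping Fluoro for Methyl: What to Expect

The source may report more compounds than this note shows. Statements on the series, on what has been measured and on what is new or still open speak of the compounds shown alone.

- Compound 1 `O=C(/C(=C\c1c[nH]c2ccccc12)S(=O)(=O)Cc1ccc(F)cc1)c1ccc(Cl)cc1`: 50000 nM
- Compound 2 `CCOc1ccc(/C=C(\C(=O)c2ccc(Cl)cc2)S(=O)(=O)Cc2ccc(F)cc2)cc1OC`: 50000 nM

In a functional assay on DU-145 cells (Homo sapiens) for inhibition, read by trypan blue exclusion, with a stated time of 96 h (on this read-out higher numbers stand for weaker inhibition of growth and lower numbers for stronger inhibition of growth), compound 1 gives 50000 nM, level with compound 2. Compound 3 `Cc1ccc(CS(=O)(=O)/C(=C/c2c[nH]c3ccccc23)C(=O)c2ccc(Cl)cc2)cc1` is still unmeasured. It differs from compound 1 by methyl in place of fluoro on an aromatic carbon, para to a large group. For the measured compounds named here, the only measured step, no change at the digits printed from compound 1 to compound 2 (within the scatter), changes another place, so it offers indirect guidance and no measured step covers this position. The expected result is a 1.3-fold lower number from compound 1 to compound 3 (0.10 log units; within the scatter), with no shift beyond the scatter in either direction. For compound 3 the estimated value is 40000 nM, with an expected range from 8000 nM to 60000 nM.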

Compound 3, concentration for 50% growth inhibition: 25000 nM
Compound 3: middle estimate off by 1.6-fold (0.20 log units), on the high side; the range from low to high includes it.
By their numbers in this assay, from the lowest: compounds 3, 1 and 2 (each within the scatter of the next).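

This position now has a measured step of its own: in this assay, methyl in place of fluoro on an aromatic carbon, para to a large group, gives a 2.0-fold lower number from compound 1 to compound 3 (0.30 log units; within the scatter) and so does not shift growth inhibition beyond the scatter. On the core of compound 1, these two groups can therefore be exchanged here without a clear change in this read-out. Nothing measured here gives a reason for this result.

From the compounds shown here alone, whether an amine or a carboxylic acid at this place would move the number beyond the scatter remains open. Going by these compounds, it is also open whether the same exchange would read alike on compound 2.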